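This account rests on a few compounds, and the source may have more. Where it says the series, first, only, none or still open, it means among the compounds named here.

Measured so far:
compound 1 `Cc1cc(S(N)(=O)=O)ccc1NC(=O)COc1ccc2ccccc2c1C(=O)c1cccc(Cl)c1` — 37400 nM
compound 2 `Cc1ccc(C(=O)c2c(OCC(=O)Nc3ccc(S(N)(=O)=O)cc3C)ccc3ccccc23)c(C)c1` — 25500 nM

In an ADME assay on C8166 cells (Homo sapiens) for cytotoxicity, read by colorimetric assay and MTT assay (a lower number here means that less compound is tolerated, a higher number that more compound is tolerated), compound 2 gives the lowest of the two numbers, and compound 1 sits close to it: the step of a 1.5-fold lower number from compound 1 to compound 2 (0.17 log units; within the scatter) is within the scatter, so the two cannot be placed in an order. Compound 3 `Cc1cc(S(N)(=O)=O)ccc1NC(=O)COc1ccc2ccccc2c1C(=O)c1cc(Cl)cc(Br)c1` is the unmeasured compound; the change from compound 2 is 3-bromo-5-chlorophenyl in place of 2,4-dimethylphenyl on a carbonyl carbon. Within the data shown here, only the one measured step bears on it, and it was small, so no shift beyond the scatter is expected for this assay. Compound 3 is estimated at 33000 nM, with a range from 12000 nM to 90000 nM, meaning an expected step of a 1.3-fold higher number from compound 2 to compound 3 (0.11 log units; within the scatter).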

Compound 3, half-maximal cytotoxic concentration: 36600 nM
Beside the measured number, compound 3's estimate is 1.1-fold (0.04 log units) below it; the measured number falls inside the stated range.
By their numbers in this assay, from the lowest: compounds 2, 3 and 1 (each within the scatter of the next).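

In this assay, replacing the whole ring on the carbonyl carbon gives a 1.4-fold higher number from compound 2 to compound 3 (0.16 log units; within the scatter). Adding one halogen, bromo in place of hydrogen on an aromatic carbon, gives a 1.0-fold lower number from compound 1 to compound 3 (0.01 log units; within the scatter). Neither change moves the number beyond the scatter, so among these three compounds, this position accepts both methyl and halogen substituents on the ring without a readable shift, and no further measurement bears on this result. Still open, going by these compounds, is whether a ring carrying an amine or a carboxylic acid on this carbonyl carbon would give a number beyond the scatter.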